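The compounds below may be only part of what the source reports. "The series", "measured", "known", "first", "only" and "open" are said of these compounds alone.

Measured so far in a functional assay on A375P cells (Homo sapiens) for inhibition, read by MTT assay, with a stated time of 24 h; a higher number here means a weaker inhibitor of growth, a lower number a stronger inhibitor of growth:
compound 1 `O=C1CC(c2ccc(NC(=O)c3ccc(Cl)c(C(F)(F)F)c3)cc2)=Nc2cnn(Cc3ccccc3)c2N1`: 13100 nM
compound 2 `O=C1CC(c2ccc(NC(=O)Nc3ccc(Cl)c(C(F)(F)F)c3)cc2)=Nc2cnn(Cc3ccccc3)c2N1`: 1190 nM
compound 3 `O=C1CC(c2ccc(NC(=O)Nc3ccc(Cl)c(C(F)(F)F)c3)cc2)=Nc2cn[nH]c2N1`: a limit only, > 30000 nM

Compound 2 stands lowest of the two numbers in this assay; the nearest number is that of compound 1, and the step is an 11-fold lower number from compound 1 to compound 2 (1.04 log units; beyond the scatter). For compound 3 this assay gives only a limit, > 30000 nM, as set out in the limit of > 30000 nM in this assay, at which 1 of the 3 values shown sits.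

The next step goes from compound 2 to compound 4 `O=C1CC(c2ccc(NC(=O)Nc3cccc(Cl)c3)cc2)=Nc2cnn(Cc3ccccc3)c2N1`. The change is 3-chlorophenyl in place of 4-chloro-3-(trifluoromethyl)phenyl on an amide-type nitrogen. Neither measured step touches this part of the molecule: an 11-fold lower number from compound 1 to compound 2 (1.04 log units; beyond the scatter) exchanges the group on the carbonyl carbon, and an at least 25-fold higher number from compound 2 to compound 3 (1.40 log units; beyond the scatter) exchanges the group on the aromatic nitrogen, while the 4-chloro-3-(trifluoromethyl)phenyl group is the same in compounds 1, 2 and 3. For the measured compounds named here, no measured step therefore bears on the change to compound 4, and the expectation rests on the number for compound 2 alone, with a wide range that allows a step beyond the scatter in either direction.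

Compound 4 is expected to give about 4000 nM in this assay, between 1000 nM and 20000 nM. This estimate means a step of a 3.4-fold higher number from compound 2 to compound 4 (0.53 log units; beyond the scatter), taken as the best guess in the absence of any bearing step.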

Compound 4, concentration for 50% growth inhibition: 2070 nM
Beside the measured number, compound 4's estimate is 1.9-fold (0.29 log units) above it; the range from low to high includes it.
By their numbers in this assay, from the lowest: compounds 2 and 4 (each within the scatter of the next); then compound 1. At a limit, above all of these: compound 3.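

In this assay, the group on the amide-type nitrogen can be exchanged without a change that stands out from the scatter: a 1.7-fold higher number from compound 2 to compound 4 (0.24 log units; within the scatter). The trifluoromethyl-bearing 4-chloro-3-(trifluoromethyl)phenyl group is therefore not required to keep this level of growth inhibition, at least when the 3-chlorophenyl group takes its place and the benzyl group and the rest of the core stay as they are. The advantage over compound 1 also no longer rests on a single aryl group, since a (3-chlorophenyl)amino group in place of the 4-chloro-3-(trifluoromethyl)phenyl group on the carbonyl carbon gives a 6.3-fold lower number from compound 1 to compound 4 (0.80 log units; beyond the scatter), a modest step, while nothing recorded here gives a cause for either result.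

Still open, as far as these compounds go, is whether the chlorine matters at all on this ring, which a plain phenyl, a 3-(trifluoromethyl)phenyl or a phenyl carrying an amine or a carboxylic acid would settle. From the compounds shown here alone, compound 3, with hydrogen on the aromatic nitrogen, gives only a limit, > 30000 nM, so what a longer chain or a carboxylic acid on that nitrogen would give also stays open.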